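A Cyanoacetate Ester Replaces the Aldehyde

The source may hold more compounds than are shown below. What is called first, only, known or untested is meant among the compounds shown, and "the series" means these compounds.

Going by the values given here, compound 2 `O=CCc1c(-c2ccccc2Cl)c2cc(Cl)ccc2[nH]c1=O` carries a formylmethyl side chain on the shared core and is the only compound with a number in an ADME assay on HepG2 2.2.15 cells (Homo sapiens) for cytotoxicity; on this read-out lower numbers stand for higher toxicity in this test and higher numbers for lower toxicity in this test: compound 2 gives 120000 nM. Compound 1 `O=c1c(CCO)c(-c2ccccc2Cl)c2cc(Cl)ccc2n1-c1c(F)cccc1F` is reported in this assay only as a limit of the assay, > 2300000 nM, as stated in the limit of > 2300000 nM in this assay, at which 1 of the 2 values shown sits. Compound 3 `N#CCC(=O)OCCc1c(-c2ccccc2Cl)c2cc(Cl)ccc2[nH]c1=O` differs from compound 2 by (((cyanomethyl)carbonyl)oxy)methyl in place of formyl on a saturated chain carbon bound to an aromatic carbon. Among the compounds with values here, no step between measured compounds is at hand, so the expectation for compound 3 is cautious: the step of a 1.7-fold higher number from compound 2 to compound 3 (0.22 log units; within the scatter) is expected to be small, toward lower toxicity, hardly beyond the scatter. Compound 3 is estimated at 200000 nM, with a range from 60000 nM to 800000 nM.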

Compound 3, half-maximal cytotoxic concentration: 100000 nM
Compound 3: the middle estimate sits 2.0-fold (0.30 log units) above what was measured; the measured number falls inside the stated range.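

In this assay, going by these compounds alone, placing (((cyanomethyl)carbonyl)oxy)methyl in place of formyl on a saturated chain carbon bound to an aromatic carbon gives a 1.2-fold lower number from compound 2 to compound 3 (0.08 log units; within the scatter), the first reading at this position. For this pair, then, the formyl group is not needed for a value of this size, and the much larger group leaves the read-out within the scatter. Nothing measured here bears on why the two compounds read alike.

From the compounds shown here alone, whether an amine or a carboxylic acid at this place would read the same stays open. So does whether the nitrile alone, without the carbonyl, would do so.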